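Bromo to Methoxy on the Urea Aryl Group

This account rests on a few compounds, and the source may have more. Where it says the series, first, only, none or still open, it means among the compounds named here.

Measured so far:
Compound 1 `Cc1ccc(NC(=O)N[C@H]2CC[C@H](Oc3ccc(F)cc3)CC2)cc1` — in a functional assay on CRL2813 cells (Homo sapiens) for cytotoxicity, read by sulforhodamine B assay, with a stated time of 5 days (on this read-out lower numbers stand for stronger inhibition and higher numbers for weaker inhibition), compound 1 reaches only an assay limit, > 20000 nM.
Compound 2 `O=C(Nc1cccc(Br)c1)N[C@H]1CC[C@H](Oc2ccc(F)cc2)CC1` — in this assay compound 2 gives 6200 nM.

Both compounds share the same core, a urea linking a cyclohexyl ether to an aromatic ring, and differ only in that ring. Among the compounds with values here, compound 2 carries the only actual number in this assay; the value of compound 1 is a limit and not a number, and the limit of > 20000 nM in this assay, at which 1 of the 2 values shown sits, marks where it sits. Within the data shown here, the single measured step, an at least 3.2-fold lower number from compound 1 to compound 2 (0.50 log units; beyond the scatter), shows that changing this aromatic ring can move the read-out beyond the scatter.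

Compound 3 `COc1ccccc1NC(=O)N[C@H]1CC[C@H](Oc2ccc(F)cc2)CC1` is the next variation: 2-methoxyphenyl in place of 3-bromophenyl on an amide-type nitrogen. The measured step from compound 1 to compound 2 is the only one that bears on it, and it involved neither the methoxy group nor its place on the ring, so it sets the scale of what a ring change can do rather than the direction. The expectation for compound 3 is therefore a modest move toward a higher number, a 1.9-fold higher number from compound 2 to compound 3 (0.29 log units; within the scatter), close to the edge of the scatter. Compound 3 is estimated at 12000 nM, with a range from 4000 nM to 40000 nM.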

Compound 3, half-maximal inhibitory concentration: > 20000 nM
Compound 3: no number, only a limit (the forecaster's own chance of this, stated with the estimate: 35%); middle value at least 1.6-fold (0.22 log units) from the limit.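

Compound 3 gives only a limit in this assay, not a number, and compound 1 reaches the same limit: the limit of > 20000 nM in this assay, at which 2 of the 3 values shown sit.

Setting 2-methoxyphenyl in place of 3-bromophenyl on the amide-type nitrogen gives an at least 3.2-fold higher number from compound 2 to compound 3 (0.50 log units; beyond the scatter), so this time a ring change moves the read-out in the opposite direction to the first measured step, and the methoxy group does not keep the number that compound 2 reached. Of the three aromatic groups shown on this nitrogen, only 3-bromophenyl gives a measured number, while 4-methylphenyl and 2-methoxyphenyl both end at the limit, and the step between those two compounds cannot be read, as two limits give no order.

The swap from compound 2 to compound 3 changes both the group on the ring and where it sits, so the compounds shown cannot tell whether the bromine itself or its place on the ring matters more. Also open, going by these compounds, is how the read-out would respond to a chlorine atom in place of the bromine, or to an amine or a carboxylic acid on this ring.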